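The compounds below may be only part of what the source reports. "The series", "measured", "known", "first", "only" and "open" are said of these compounds alone.

Measured so far in an in vitro ADME assay on microsomes from liver (Rattus norvegicus) for metabolic stability; a higher number here means faster removal of the compound, a lower number slower removal:
- compound 1 `COC(=O)[C@H]1CC[C@@H](n2/c(=N/C(=O)c3ccccc3)[nH]c3ccc(CN4CCCCC4)cc32)CC1`: 459 mL.min-1.g-1
- compound 2 `CC(C)NC(=O)[C@H]1CC[C@@H](n2/c(=N/C(=O)c3ccc(F)cc3)[nH]c3ccc(CN4CCC[C@H]4C(C)(C)O)cc32)CC1`: 455 mL.min-1.g-1

Compound 1 at 459 mL.min-1.g-1 stands level with compound 2, the two numbers lying within the scatter of each other. Compound 3 `CC(C)NC(=O)[C@H]1CC[C@@H](n2/c(=N/C(=O)c3ccccc3)[nH]c3ccc(CN4CCCCC4)cc32)CC1` keeps the core of compound 1 and changes one place: isopropylamino in place of methoxy on a carbonyl carbon, which reads as methoxycarbonyl to isopropylcarbamoyl. Among the compounds with values here, no measured pair shows this change on its own, so the expectation rests on little. Compound 2 also carries isopropylcarbamoyl and gives 455 mL.min-1.g-1, which offers no sign of a large fall in this assay for compound 3. A small move to a lower number, within the scatter, is expected, estimated as a 1.4-fold lower number from compound 1 to compound 3 (0.16 log units; within the scatter) and no more than that. Compound 3 is expected at 320 mL.min-1.g-1, with an estimated range of 150 mL.min-1.g-1 to 650 mL.min-1.g-1 and a wide margin on either side.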

Compound 3, intrinsic clearance in microsomes: 389 mL.min-1.g-1
The estimate for compound 3 lay 1.2-fold (0.08 log units) below the measured number; measured number inside the range.
By their numbers in this assay, from the lowest: compounds 3, 2 and 1 (each within the scatter of the next).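

In this assay, within the data shown here, isopropylamino in place of methoxy on a carbonyl carbon gives a 1.2-fold lower number from compound 1 to compound 3 (0.07 log units; within the scatter), the first reading of this change on its own. At this place on the core of compound 1, methoxycarbonyl and isopropylcarbamoyl are therefore not told apart by this read-out. Nothing at hand bears on why the two groups read alike.

As far as these compounds go, whether a different group on the same carbonyl carbon, such as the hydroxy of a carboxylic acid, a plain amino group or a longer chain on the amide nitrogen, would separate from compound 1 in this assay remains open. Also open, from the compounds shown here alone, is whether the same change reads alike on other cores, as this single pair covers only the core of compound 1.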